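Fluoro in Place of Ethyl on the Shared Core

The source may report more compounds than this note shows. Statements on the series, on what has been measured and on what is new or still open speak of the compounds shown alone.

Compound 1 `Cc1ccc2nc(C(=O)Nc3c(F)cc(-c4cccc(F)c4)cc3F)c(C)c(O)c2c1` gives 17.9% in a functional assay on A-375 cells (Homo sapiens) for antiproliferative activity, read by MTT assay, with a stated time of 24 h, tested at 11.11 ug/mL; a higher number here means a stronger effect of the compound at the concentration tested, a lower number a weaker effect.
Compound 2 `CCc1ccc2nc(C(=O)Nc3c(F)cc(-c4cccc(F)c4)cc3F)c(C)c(O)c2c1` gives 26.4% in this assay.

Among the measured compounds shown here, compound 2 stands at the top of these two numbers, but the only measured step, a number 8.5 percentage points higher from compound 1 to compound 2 (within the scatter), lies within the scatter, so the two compounds cannot be told apart on this evidence. Compound 3 `Cc1c(C(=O)Nc2c(F)cc(-c3cccc(F)c3)cc2F)nc2ccc(F)cc2c1O` has not yet been measured; it differs from compound 2 by fluoro in place of ethyl on an aromatic carbon. For the measured compounds named here, no measured step exchanges one group for another at this place on the shared core, and the single step available was small. Nothing in the data points to a move beyond the scatter, so the number for compound 3 is expected to sit near that of compound 2, a step of a number 5.4 percentage points lower from compound 2 to compound 3 (within the scatter) in this assay. Compound 3 is therefore estimated at 21%, within a range from 8% to 36%.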

Compound 3, a percentage reported as inhibition, at one concentration (the size of the read-out at that concentration, not a potency): 16.2%
Estimate against measurement, compound 3: 4.8 percentage points above, within the range that was stated.
By their numbers in this assay, from the lowest: compounds 3, 1 and 2 (each within the scatter of the next, the first and the last beyond it).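

Swapping ethyl for fluoro on this aromatic carbon gives a number 10.2 percentage points lower from compound 2 to compound 3 (beyond the scatter) in this assay and is the first modest step here that stands clear of the scatter. Fluoro in place of methyl at the same carbon gives a number 1.7 percentage points lower from compound 1 to compound 3 (within the scatter) and so leaves those two compounds indistinguishable, which means that only the ethyl and fluoro compounds can be told apart at this position. Nothing measured here explains this difference between ethyl and fluoro.

With only methyl, ethyl and fluoro shown at this place, it remains open how a longer chain such as propyl, a methoxy group or an amine would read in this assay at this position. All three numbers also come from one tested concentration, so they show only a stronger or weaker effect at that concentration.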